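Urea-linked series: step from compound 2 to compound 4

The source may hold more compounds than are shown below. What is called first, only, known or untested is meant among the compounds shown, and "the series" means these compounds.

Measured so far:
- compound 1, `Nc1n[nH]c2cccc(-c3cccc(NC(=O)Nc4cccc(Cl)c4)c3)c12` — 1830 nM
- compound 2, `Nc1n[nH]c2cccc(-c3cccc(NC(=O)Nc4ccc(Cl)cc4Cl)c3)c12` — 1900 nM
- compound 3, `Nc1n[nH]c2cccc(-c3cccc(NC(=O)Nc4ccc(Cl)c(C(F)(F)F)c4)c3)c12` — 1150 nM

In a functional assay on SMMC-7721 cells (Homo sapiens) for inhibition, read by MTT assay, with a stated time of 48 h (a lower number here means a stronger inhibitor, a higher number a weaker inhibitor), compound 2 gives the highest of the three numbers, but its nearest neighbour, compound 1, sits within the scatter of it, and so does compound 3 at the far end; nothing here separates the three compounds beyond the scatter. Going by the values given here, the only single-point step measured in the set, a 1.0-fold higher number from compound 1 to compound 2 (0.02 log units; within the scatter), changed the aryl group on the amide-type nitrogen and produced no movement beyond the scatter.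

Compound 4, `Nc1n[nH]c2cccc(-c3cccc(NC(=O)Nc4cccc(F)c4)c3)c12`, is not yet measured. It differs from compound 2 by 3-fluorophenyl in place of 2,4-dichlorophenyl on an amide-type nitrogen. Among the compounds with values here, the step from compound 1 to compound 2 is the one measured comparison bearing on this change, since it also swaps the aryl group at the same place; it was flat. Compound 4 also returns to a single halogen at the same position of the ring as in compound 1, whose value in this assay is 1830 nM. The step from compound 2 to compound 4 is therefore expected to be small, a 1.1-fold higher number from compound 2 to compound 4 (0.02 log units; within the scatter), with no direction beyond the scatter. Compound 4 is estimated at 2000 nM, within 900 nM to 4500 nM.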

Compound 4, half-maximal inhibitory concentration: 1240 nM
Beside the measured number, compound 4's estimate is 1.6-fold (0.21 log units) above it, within the range that was stated.
By their numbers in this assay, from the lowest: compounds 3, 4, 1 and 2 (each within the scatter of the next).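

In this assay, the exchange of 2,4-dichlorophenyl for 3-fluorophenyl on an amide-type nitrogen gives a 1.5-fold lower number from compound 2 to compound 4 (0.19 log units; within the scatter), so a second change of the aryl group at this place also stays within the scatter. The series now also holds a change of the halogen alone, fluoro in place of chloro on an aromatic carbon, which gives a 1.5-fold lower number from compound 1 to compound 4 (0.17 log units; within the scatter) and likewise does not separate the two compounds. No measurement at hand accounts for these results.

The compounds shown carry halogen or trifluoromethyl on this aryl group, so it stays open whether any group here can move the number beyond the scatter. A methoxy group, an amine or a carboxylic acid on that ring, or a longer chain in place of the aryl group, would address this.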